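The source may report more compounds than this note shows. Statements on the series, on what has been measured and on what is new or still open speak of the compounds shown alone.

Compound 1, `Cc1ccccc1Oc1ccc(N2C[C@@H](C(F)(F)F)C[C@H]2CC(=O)O)cc1`, is the most potent of the three measured compounds in a functional assay on cells for agonist activity at Free fatty acid receptor 1 (Mus musculus), read by FLIPR and calcium flux, with a stated time of 100 s (a lower number here means that less compound is needed, a higher number that more compound is needed for the effect), where compound 1 gives 330 nM. Compound 3, `Cc1cc(OCc2ccccc2)ccc1Oc1ccc(N2C[C@@H](C(F)(F)F)C[C@H]2CC(=O)O)cc1`, gives 1500 nM in this assay, and compound 2, `Cc1ccccc1Oc1ccc(N2CCC[C@H]2CC(=O)O)cc1`, gives 5600 nM.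

The unmeasured compound 4, `COc1ccc(F)c(Cc2cccc(Oc3ccc(N4C[C@@H](C(F)(F)F)C[C@H]4CC(=O)O)cc3)c2C)c1`, differs from compound 1 by 2-fluoro-5-methoxybenzyl in place of hydrogen on an aromatic carbon. Among the compounds with values here, the step that bears most on this change is the one from compound 1 to compound 3, where a benzyloxy group was added to the same aromatic ring of the shared core and the number rose by a 4.5-fold higher number from compound 1 to compound 3 (0.66 log units; beyond the scatter). The step of a 17-fold higher number from compound 1 to compound 2 (1.23 log units; beyond the scatter) concerns the trifluoromethyl on the saturated ring, which compound 4 keeps, so it does not bear on this change. A large aromatic addition on this ring has so far cost potency, although compound 4 carries its addition at a different aromatic carbon, so only a modest rise is expected in this assay, as a 2.3-fold higher number from compound 1 to compound 4 (0.36 log units; beyond the scatter). Compound 4 is therefore estimated at 750 nM, within a range of 200 nM to 2800 nM.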

Compound 4, half-maximal effective concentration: 780 nM
Compound 4: middle estimate off by 1.0-fold (0.02 log units), on the low side, within the range that was stated.
By their numbers in this assay, from the lowest: compound 1; then compounds 4 and 3 (each within the scatter of the next); then compound 2.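

In this assay, within the data shown here, placing 2-fluoro-5-methoxybenzyl on the aromatic carbon ortho to a methyl group gives a 2.4-fold higher number from compound 1 to compound 4 (0.37 log units; beyond the scatter), so a large addition carries a cost at this carbon as well as at the one bearing benzyloxy in compound 3. That step is modest, as is a 4.5-fold higher number from compound 1 to compound 3 (0.66 log units; beyond the scatter), and neither addition to this ring lowers the number; no compound shown goes against this. The data shown offer no explanation for the rise. The compounds leave open how a plain benzyl, a methyl or an aminomethyl group would behave at this carbon, and therefore whether the cost belongs to the benzyl group as a whole or to its fluorine or methoxy substituent. They also leave open whether removing the trifluoromethyl would have the same effect with 2-fluoro-5-methoxybenzyl in place.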